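Amide substituent swap on the alkyne-pyridine series

This account rests on a few compounds, and the source may have more. Where it says the series, first, only, none or still open, it means among the compounds named here.

Measured compounds:
- compound 1 `C[C@@H](NC(=O)c1ccc(C#Cc2ccccc2F)cn1)C(C)(C)O`: 60%
- compound 2 `CC(C)[C@@H](C)NC(=O)c1ccc(C#Cc2cccc(F)c2)cn1`: 69.3%

In a functional assay on HEK293 cells for positive allosteric modulation of metabotropic glutamate receptor 5 (Rattus norvegicus), read by fluorescence and calcium flux (on this read-out lower numbers stand for smaller maximal responses and higher numbers for larger maximal responses), compound 1 gives 60%. In this assay compound 2 gives 69.3%. The two numbers lie within the usual scatter of one another, so no order between compound 1 and compound 2 can be read from them; they share the amide-linked alkyne-pyridine core and differ both in the amide substituent and in the placement of the fluorine on the outer ring, so the difference is not attributed to any one change.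

Compound 3 `CC(C)(C)CNC(=O)c1ccc(C#Cc2cccc(F)c2)cn1` keeps the core and the fluorine pattern of compound 2 and changes only the group on the amide nitrogen: neopentyl in place of 1,2-dimethylpropyl on an amide-type nitrogen. The two groups carry the same count of carbon atoms, no ring, no donors or acceptors, and the only counted loss is the single defined stereocentre.

For the measured compounds named here, nothing measured so far separates two amide substituents of this kind, so no step beyond the scatter is expected in either direction. Compound 3 is expected to give 65%, within a range of 45% to 85%. The expected step, a number 4.3 percentage points lower from compound 2 to compound 3 (within the scatter), is estimated to stay within the scatter.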

Compound 3, largest response reached (reported as efficacy), in percent of the reference or control that the assay uses: 63.9%
The estimate for compound 3 lay 1.1 percentage points above the measured number; measured number inside the range.
By their numbers in this assay, from the lowest: compounds 1, 3 and 2 (each within the scatter of the next).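

In this assay, for the compounds shown here, neopentyl in place of 1,2-dimethylpropyl on the amide-type nitrogen gives a number 5.4 percentage points lower from compound 2 to compound 3 (within the scatter), the first comparison that differs in one place only. The two groups have the same count of heavy atoms, so this pair tests a rearrangement of the five carbons together with the loss of the single defined stereocentre, and neither shows a readable effect on maximal response here: compound 3 has no defined stereocentre, yet its value cannot be separated from that of compound 2. No supporting data bear on this result, so the absence of a step stands as an observation without an explanation.

Going by these compounds, the separate contributions of the hydroxyl-bearing amide substituent of compound 1 and of its fluorine placement remain open, since compound 1 differs from compound 2 and compound 3 in more than one place. Also open, on these data alone, is whether a cyclohexyl ring, a longer chain such as n-octyl, or a carboxylic acid on this amide nitrogen would give a step beyond the scatter.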